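The source may hold more compounds than are shown below. What is called first, only, known or untested is meant among the compounds shown, and "the series" means these compounds.

Measured compounds:
compound 1 `COc1cc(CCC(=O)N2CCN(C(=O)c3cc(OC)c(OC)c(OC)c3)CC2)cc(OC)c1OC`: > 5 mg/kg
compound 2 `O=C(CC(c1ccccc1)c1ccccc1)N1CCN(Cc2cccnc2)CC1`: 0.48 mg/kg

Going by the values given here, in a functional assay for antagonist activity at platelet-activating factor receptor (Rattus norvegicus) (on this read-out higher numbers stand for an effect only at larger amounts of compound and lower numbers for an effect already at smaller amounts), compound 2 gives 0.48 mg/kg, the only number in this set. For compound 1 only a limit is known: the limit of > 5 mg/kg in this assay, at which 1 of the 2 values shown sits. Compound 3 `O=C(CC(c1ccccc1)c1ccccc1)N1CCN(S(=O)(=O)c2ccncc2)CC1` differs from compound 2 by (pyridin-4-yl)sulfonyl in place of (pyridin-3-yl)methyl on an amine nitrogen in a ring. Among the compounds with values here, no step between measured compounds is available, so the size of this change is an open question. Compound 3 is expected near 1 mg/kg, range 0.25 mg/kg to 5 mg/kg. The expected step of a 2.1-fold higher number from compound 2 to compound 3 (0.32 log units; beyond the scatter) is modest and may stay within the scatter.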

Compound 3, dose for 50% inhibition: > 5 mg/kg
Compound 3 ended at the assay's limit; the forecaster's own chance of this, stated with the estimate: 20%; middle value at least 5.0-fold (0.69 log units) away from the limit.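

In this assay, (pyridin-4-yl)sulfonyl in place of (pyridin-3-yl)methyl on the amine nitrogen in the ring gives an at least 10-fold higher number from compound 2 to compound 3 (1.01 log units; beyond the scatter). A six-membered aromatic ring with 1 hetero atom stands on both sides of this change, so its presence alone does not hold the effect at this position. Compound 3 stands at a limit and not at a number, so the true size of the step stays unknown: the limit of > 5 mg/kg in this assay, at which 2 of the 3 values shown sit.

The change replaces the link to the nitrogen and the attachment point on the pyridine together, leaving the share of each open. A (pyridin-3-yl)sulfonyl or (pyridin-4-yl)methyl group on the same nitrogen would separate the two.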